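Cytotoxicity notes on the oxalamide series, compound 1 to compound 4

The compounds below may be only part of what the source reports. "The series", "measured", "known", "first", "only" and "open" are said of these compounds alone.

Compounds already measured in an ADME assay on MT2 cells (Homo sapiens) for cytotoxicity, read by XTT assay, with a stated time of 4 days; a lower number here means that less compound is tolerated, a higher number that more compound is tolerated:
compound 1 `Cc1ccc(NC(=O)C(=O)NC(c2nc(C)c(CO)s2)C2CCCCN2)cc1F`
compound 2 `Cc1nc(C(NC(=O)C(=O)Nc2ccc(Cl)cc2)C2CCNCC2)sc1CCO`
compound 3 `Cc1ccc(NC(=O)C(=O)NC(c2nc(C)c(CCO)s2)C2CCCCN2)cc1F`

Compound 1 reaches only a limit in this assay, > 88000 nM. Compound 2 likewise returns only a limit, > 78500 nM. Compound 3 gives a number, 85000 nM. Among the compounds with values here, the single measured step, an at least 1.0-fold lower number from compound 1 to compound 3 (0.01 log units; that floor lies within the scatter), stays within the scatter, and no measured pair touches the aryl group, so nothing directly bears on the present change. Compound 4 `Cc1nc(C(NC(=O)C(=O)Nc2ccc(F)cc2)C2CCCCN2)sc1CO` carries 4-fluorophenyl in place of 3-fluoro-4-methylphenyl on an amide-type nitrogen. With every value shown sitting at or near the tolerance ceiling, the expected step is an at least 1.0-fold lower number from compound 1 to compound 4 (0.01 log units; that floor lies within the scatter), none beyond the scatter, and most likely a limit once more. Compound 4 is estimated at 85000 nM, within 40000 nM to 200000 nM.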

Compound 4, half-maximal cytotoxic concentration: > 113000 nM
Compound 4: no number, only a limit; the forecaster's own chance of this, stated with the estimate: 70%; at least 1.3-fold (0.12 log units) between middle value and limit.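

Compound 1 and compound 4 both return only limits in this assay, so the step between them cannot be read. The compounds shown leave open whether 4-fluorophenyl in place of 3-fluoro-4-methylphenyl changes the tolerated concentration at all.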